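This account rests on a few compounds, and the source may have more. Where it says the series, first, only, none or still open, it means among the compounds named here.

Measured in a functional assay on HT-29 cells (Homo sapiens) for cytotoxicity, read by sulforhodamine B assay, with a stated time of 72 h; a higher number here means a weaker inhibitor, a lower number a stronger inhibitor:
compound 1 `COc1cc2ncnc(Nc3ccc(F)c(Cl)c3)c2cc1OCCCCn1ccnc1[N+](=O)[O-]` gives 1620 nM
compound 2 `C#Cc1cccc(Nc2ncnc3cc(OC)c(OCCCCn4ccnc4[N+](=O)[O-])cc23)c1` gives 6900 nM
compound 3 `COc1cc2ncnc(Nc3ccc(OCc4cccc(F)c4)c(Cl)c3)c2cc1OCCCCn1ccnc1[N+](=O)[O-]` gives 2070 nM

Compound 1 has the lowest number of the three. Compound 3 sits within the scatter of it, the step being a 1.3-fold higher number from compound 1 to compound 3 (0.11 log units; within the scatter). Compound 2 stands apart, through a 4.3-fold higher number from compound 1 to compound 2 (0.63 log units; beyond the scatter).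

Compound 4 `COc1cc2ncnc(Nc3ccc(F)c(Cl)c3)c2cc1OCCCCn1c([N+](=O)[O-])cnc1C` differs from compound 1 only by 2-methyl-5-nitro-1H-imidazol-1-yl in place of 2-nitro-1H-imidazol-1-yl on a saturated chain carbon, four bonds along the chain from an oxygen on an aromatic ring. Both measured steps alter the group on a nitrogen on an aromatic ring or its substituent, not the 2-nitro-1H-imidazol-1-yl end of the chain; neither bears on this change. No comparison for it exists in the set. In this assay the expected step is therefore a 1.0-fold higher number from compound 1 to compound 4 (0.02 log units; within the scatter), not beyond the scatter in either direction. Compound 4 is estimated at 1700 nM, with a range from 600 nM to 5000 nM.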

Compound 4, half-maximal inhibitory concentration: 9980 nM
The estimate for compound 4 lay 5.9-fold (0.77 log units) below the measured number; measured number above the stated range.
By their numbers in this assay, from the lowest: compounds 1 and 3 (each within the scatter of the next); then compounds 2 and 4 (each within the scatter of the next).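

In this assay, going by these compounds alone, the chain end proves sensitive to change: 2-methyl-5-nitro-1H-imidazol-1-yl in place of 2-nitro-1H-imidazol-1-yl gives a 6.2-fold higher number from compound 1 to compound 4 (0.79 log units; beyond the scatter), a step beyond the scatter at a place the earlier compounds left unchanged. The entering group differs in both its added methyl and its nitro position, and this single pair cannot separate the two. No measurement available here accounts for the step.
Open, going by these compounds, is whether a 5-nitro-1H-imidazol-1-yl group without the methyl behaves like compound 1 or compound 4. On these data alone, the effect of a longer chain carrying either group also remains open.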